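Fluoro to trifluoromethyl, read across two cores

The source may report more compounds than this note shows. Statements on the series, on what has been measured and on what is new or still open speak of the compounds shown alone.

Compound 2 `Cc1ccnc(NC(c2ccc(F)cc2)c2ccc3cccnc3c2O)c1` and compound 1 `Cc1ccnc(NC(c2ccc(C(F)(F)F)cc2)c2ccc3cccnc3c2O)c1` share one core and differ only by trifluoromethyl in place of fluoro on an aromatic carbon. In an assay for inhibition of protein disulfide-isomerase (Homo sapiens), with a stated time of 1 h (on this read-out higher numbers stand for weaker inhibition and lower numbers for stronger inhibition), compound 2 gives 140 nM, while compound 1 gives 26500 nM; the step between them is a 190-fold higher number from compound 2 to compound 1 (2.28 log units; beyond the scatter). Compound 3 `Oc1c(C(c2ccc(F)cc2)N2CCCCC2)ccc2ccoc12` stands on a different core, and the difference between the two cores is not broken down here. In this assay compound 3 gives 560 nM, the second highest of the three measured numbers. Compound 4 `Oc1c(C(c2ccc(C(F)(F)F)cc2)N2CCCCC2)ccc2ccoc12` is not yet measured and differs from compound 3 by trifluoromethyl in place of fluoro on an aromatic carbon. The place of the change reads the same for both pairs, so this is the same change, seen once so far in measured compounds, where it weakened inhibition sharply. For compound 4 the expected step is a 45-fold higher number from compound 3 to compound 4 (1.65 log units; beyond the scatter), somewhat smaller than the precedent because a 190-fold higher number from compound 2 to compound 1 (2.28 log units; beyond the scatter) was measured on another core and its full size may not carry over. Compound 4 is thus expected to give about 25000 nM in this assay, estimated between 5000 nM and 120000 nM.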

Compound 4, half-maximal inhibitory concentration: 300 nM
Compound 4: middle estimate off by 83-fold (1.92 log units), on the high side; measured number outside the range, below it.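

In this assay, trifluoromethyl in place of fluoro on the core of compound 3 gives a 1.9-fold lower number from compound 3 to compound 4 (0.27 log units; within the scatter), so this change leaves no readable difference on that core. The effect of the change therefore does not carry from one core to the other in these two pairs, and a large step read on one core gave no usable measure of the step on the other: the same change on two cores in this assay, a 190-fold higher number (2.28 log units; beyond the scatter) from compound 2 to compound 1 and a 1.9-fold lower number (0.27 log units; within the scatter) from compound 3 to compound 4, 350-fold (2.55 log units) apart, beyond the scatter of two such steps

This shows that the outcome depends on the core for these four compounds, but two pairs give no rule for the series and do not show which part of the cores sets the gap, nor how the change would read on a further core.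

Still open, as far as these compounds go, is whether a chloro or a methoxy group at the same place would separate the two cores in the same way. Also open, from the compounds shown here alone, is whether the gap follows each core as a whole or a single part of it.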